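Series notes: from compound 2 to compound 3

The source may hold more compounds than are shown below. What is called first, only, known or untested is meant among the compounds shown, and "the series" means these compounds.

Two compounds in the set carry a measurement in an ADME assay on J774.1 cells (Mus musculus) for cytotoxicity, with a stated time of 48 h; a lower number here means that less compound is needed, a higher number that more compound is needed for the effect. Compound 1 `COC(=O)C1C(=O)C(C(=O)OC)[C@H](c2cccc([N+](=O)[O-])c2)N(Cc2ccc(Cl)cc2)[C@@H]1c1cccc([N+](=O)[O-])c1` gives 46.6 uM. Compound 2 `C=CCN1[C@@H](c2ccccn2)CC(O)=C(C(=O)OC)[C@H]1c1ccccn1` gives 35 uM in this assay, and the number for compound 1 sits within the usual scatter of that value, so the two compounds cannot be told apart on the readings at hand. Among the measured compounds shown here, no pair of measured compounds differs in a single place, so the set offers no step of known size.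

Compound 3 `COC(=O)C1=C(O)C[C@H](c2ccccn2)N(Cc2cccc(OC)c2)[C@@H]1c1ccccn1` has not been measured in this assay. It differs from compound 2 by 3-methoxyphenyl in place of vinyl on a saturated chain carbon bound to an amine nitrogen in a ring. For the measured compounds named here, compound 1 also contains a six-membered aromatic ring of carbon only that compound 2 lacks, and its number is close to that of compound 2, which is the only point of reference for this kind of change. The step expected from this change, a 1.1-fold lower number from compound 2 to compound 3 (0.04 log units; within the scatter), is expected to stay within the scatter, with no settled direction. For compound 3 the estimate in this assay is 32 uM, with a range from 13 uM to 80 uM.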

Compound 3, concentration for half-maximal effect: > 100 uM
Compound 3: no number, only a limit (the forecaster's own chance of this, stated with the estimate: 5%); at least 3.1-fold (0.49 log units) between middle value and limit.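

Working notes on the N-substituent: at the place on a saturated chain carbon bound to an amine nitrogen in a ring, 3-methoxyphenyl in place of vinyl gives an at least 2.8-fold higher number from compound 2 to compound 3 (0.45 log units; beyond the scatter) in this assay, so a change at this place can move the read-out beyond the scatter. Compound 3 gives only a limit of the assay, > 100 uM, not a number: the limit of > 100 uM in this assay, at which 1 of the 3 values shown sits. The earlier compounds shown here offered no single-place step, so this pair supplies the only measured direction in the set: with 3-methoxybenzyl in place of allyl, more compound is needed for the effect, a finding that rests on this one pair.

On these data alone, the true size of the step remains open, since only its lower bound is known. The compounds shown also leave open whether the step belongs to the aromatic ring or to the methoxy group, which a plain benzyl at this place would separate, and whether a longer chain or a chain ending in an amine would shift the number in the same direction.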